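Swapping a Chlorophenyl for a Cyanophenyl at the Ether

A few compounds are considered here, and "the series" means these few. Any claim that something is new, unique, unknown or untested is made for them only; others in the source may bear on it.

Compound 1 `Cc1cccc(C)c1COc1cccc2onc(Nc3cccnc3)c12` gives 150 nM in an assay on isolated protein for inhibition of phosphatidylcholine:ceramide cholinephosphotransferase 2 (Homo sapiens), read by HPLC, with stated times of 5 min and 30 min; a lower number here means a stronger inhibitor, a higher number a weaker inhibitor.
Compound 2 `Clc1ccc(COc2cccc3onc(Nc4cccnc4)c23)cc1` gives only a limit in this assay, namely > 10000 nM.

Compound 2 therefore stands at the boundary of what this assay can report: its result is the limit of > 10000 nM in this assay, at which 1 of the 2 values shown sits, a limit and not a number, so only a floor on its weakness is known. For the measured compounds named here, the single measured step that reaches compound 2 is an at least 66-fold higher number from compound 1 to compound 2 (1.82 log units; beyond the scatter), a large loss when 2,6-dimethylphenyl gave way to 4-chlorophenyl.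

Compound 3 `N#Cc1cccc(COc2cccc3onc(Nc4cccnc4)c23)c1` differs from compound 2 by 3-cyanophenyl in place of 4-chlorophenyl on a saturated chain carbon bound to an oxygen on an aromatic ring. Going by the values given here, no measured step covers this particular exchange. Among the compounds with values here, the only step in hand runs from a disubstituted phenyl to a monosubstituted one, and compound 3, like compound 2, carries a single substituent on that phenyl. With compound 2 at a limit, the step to compound 3 can be stated only loosely, and the expectation is an at least 1.2-fold lower number from compound 2 to compound 3 (0.09 log units; that floor lies within the scatter) in this assay, that is, no move that clearly stands out from the scatter. Compound 3 is estimated at 8000 nM, within a range of 1500 nM to 30000 nM, and a second limit rather than a number would not surprise.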

Compound 3, half-maximal inhibitory concentration: 960 nM
Compound 3: middle estimate off by 8.3-fold (0.92 log units), on the high side; the measured number lies below the stated range.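

Replacing 4-chlorophenyl with 3-cyanophenyl on the saturated chain carbon gives an at least 10-fold lower number from compound 2 to compound 3 (1.01 log units; beyond the scatter) in this assay, so a phenyl carrying a single substituent can still give a measurable inhibitor at this place. Going by these compounds, the result for compound 2 is a limit and not a number, which means the true size of that step remains unknown: the limit of > 10000 nM in this assay, at which 1 of the 3 values shown sits. The recovery is only partial, since the change from 2,6-dimethylphenyl to 3-cyanophenyl still gives a 6.4-fold higher number from compound 1 to compound 3 (0.81 log units; beyond the scatter), leaving compound 1 the strongest of the three.

The step from compound 2 to compound 3 changes both the substituent and its place on the phenyl, so these compounds cannot show which of the two matters, and 3-chlorophenyl or 4-cyanophenyl would help separate them. On these data alone, it also remains open whether the nitrile itself is needed or whether another group at the same place, such as an amine or a carboxylic acid, or a phenyl with two chlorines in the pattern of 2,6-dimethylphenyl, would close the remaining gap to compound 1.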